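Methyl for chloro on the benzoyl ring: one step seen, one awaited

A few compounds are considered here, and "the series" means these few. Any claim that something is new, unique, unknown or untested is made for them only; others in the source may bear on it.

Measured compounds:
compound 1 `N#Cc1c(Cl)c(Cl)c(C(C(=O)c2ccc(Cl)cc2)=C2NCCN2)c(C#N)c1Cl`: 0.5 ug/mL
compound 2 `N#Cc1c(F)c(Cl)c(C(C(=O)c2ccc(Cl)cc2)=C2NCCN2)c(C#N)c1F`: 0.3 ug/mL
compound 3 `Cc1ccc(C(=O)C(=C2NCCN2)c2c(Cl)c(Cl)c(C#N)c(Cl)c2C#N)cc1`: 15.7 ug/mL

All three were tested in a functional assay on HL-60 cells (Homo sapiens) for antiproliferative activity, read by MTT assay; a lower number here means a stronger inhibitor, a higher number a weaker inhibitor. Compound 1 gives 0.5 ug/mL, compound 2 gives 0.3 ug/mL, and compound 3 gives 15.7 ug/mL. Compound 2 and compound 1 lie within the usual scatter of each other; the difference between their two cores is not broken down here.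

Compound 3 differs from compound 1 in a single place: methyl in place of chloro on an aromatic carbon. That change made a 31-fold higher number from compound 1 to compound 3 (1.50 log units; beyond the scatter), a large loss of potency.

Compound 4 `Cc1ccc(C(=O)C(=C2NCCN2)c2c(Cl)c(F)c(C#N)c(F)c2C#N)cc1` has not yet been measured. It stands to compound 2 as compound 3 stands to compound 1: methyl in place of chloro on an aromatic carbon. The place is the same word for word, so this is the same change, made on the core of compound 2.

For compound 4 the expected step is a 30-fold higher number from compound 2 to compound 4 (1.48 log units; beyond the scatter), because the same change gave a 31-fold higher number from compound 1 to compound 3 (1.50 log units; beyond the scatter) on the other core. Compound 4 is therefore estimated at 9 ug/mL, most likely between 3 ug/mL and 30 ug/mL. Within the data shown here, only one earlier example supports this expectation.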

Compound 4, half-maximal inhibitory concentration: 0.03 ug/mL
Estimate against measurement, compound 4: 300-fold (2.48 log units) above; measured number below the stated range.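

Replacing chloro with methyl on the core of compound 2 gave a 10-fold lower number from compound 2 to compound 4 (1.00 log units; beyond the scatter) in this assay, so the same swap that weakened compound 1 strengthened compound 2. Set side by side, the two results differ in direction and by more than ordinary assay variation: the same change on two cores in this assay, a 31-fold higher number (1.50 log units; beyond the scatter) from compound 1 to compound 3 and a 10-fold lower number (1.00 log units; beyond the scatter) from compound 2 to compound 4, 310-fold (2.50 log units) apart, beyond the scatter of two such steps

Among these compounds, this shows that, in this small series, the effect of going from 4-chlorophenyl to 4-methylphenyl cannot be carried from one core to the other, but it does not show which feature of the cores causes the reversal, and with only one pair on each core it gives no general rule.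

The compounds shown leave open whether a methoxy group or an amine at the same place on this ring would give a step in the same direction on both cores or would also differ between them. Also open, from the compounds shown here alone, is how the swap from chloro to methyl would behave on a third core.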